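The compounds below may be only part of what the source reports. "The series", "measured", "known", "first", "only" and "open" are said of these compounds alone.

Compound 3 `CN1CC[C@@H](c2ccc(Cl)cc2)[C@H](C(=O)NCc2ccc(CNC(=O)c3ccc(Cl)cc3)cc2)C1` holds the highest of the two numbers in hand: in an assay on a subcellular fraction from brain for inhibition of Norepinephrine transporter (Rattus norvegicus) (on this read-out higher numbers stand for weaker inhibition and lower numbers for stronger inhibition), compound 3 gives 1540 nM. Compound 2 `CN1CC[C@@H](c2ccc(Cl)cc2)[C@H](C(=O)NCc2ccc(CNC(=O)[C@@H]3CN(C)CC[C@H]3c3ccc(Cl)cc3)cc2)C1`, which carries a second copy of the core on the far amide, gives 74 nM in this assay, so the two values sit well apart. Compound 1 `CN1CC[C@@H](c2ccc(Cl)cc2)[C@H](C(=O)NCc2ccc(CNC(=O)/C=C/c3ccc(Cl)cc3)cc2)C1`, with 2-(4-chlorophenyl)ethenyl on that carbonyl carbon, reaches only a limit in this assay, compound 1 giving > 2000 nM. That value is the assay limit, (the limit of > 2000 nM in this assay, at which 1 of the 3 values shown sits).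

Compound 4 `CN1CC[C@@H](c2ccc(Cl)cc2)[C@H](C(=O)NCc2ccc(CNC(=O)CCc3ccccc3)cc2)C1` differs from compound 3 by phenethyl in place of 4-chlorophenyl on a carbonyl carbon. Going by the values given here, the one measured step at this position, an at least 1.2-fold lower number from compound 1 to compound 3 (0.11 log units; that floor lies within the scatter), starts from a limit and therefore only shows that the aryl carbonyl and the aryl-ethenyl carbonyl both leave the series weak here. Phenethyl brings a saturated two-carbon link and removes the chlorine; no measured pair speaks to either change on its own. Compound 4 is therefore expected to remain in the weak region, with a step of a 1.4-fold higher number from compound 3 to compound 4 (0.15 log units; within the scatter) that is estimated to stay within the usual scatter or run slightly toward weaker inhibition. The estimate for compound 4 in this assay is 2200 nM, expected between 700 nM and 7000 nM, with a real chance that only a limit is reported.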

Compound 4, inhibition constant: > 1000 nM
Compound 4 was reported as a limit; the forecaster's own chance of this, stated with the estimate: 45%; the middle value is on the limit's open side.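

In this assay compound 4 gives > 1000 nM, and this value is a limit. Neither the step from compound 3 to compound 4 nor the step from compound 1 to compound 4 can be read. The compounds shown leave open how phenethyl on the carbonyl carbon compares with 4-chlorophenyl or 2-(4-chlorophenyl)ethenyl there.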